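A few compounds are considered here, and "the series" means these few. Any claim that something is new, unique, unknown or untested is made for them only; others in the source may bear on it.

Within the data shown here, only two compounds have a reading so far. In a functional assay on SMMC-7721 cells (Homo sapiens) for inhibition, read by MTT assay, with a stated time of 48 h (a lower number here means a stronger inhibitor, a higher number a weaker inhibitor), compound 1 `O=C(Nc1ccccn1)Nc1cc(-c2cncnc2)ccc1OC(F)(F)F` gives 21600 nM. Compound 2 `O=C(Nc1ccncc1)Nc1cc(-c2cccnc2)ccc1OC(F)(F)F` gives 42800 nM, and this value lies within the scatter of the value for compound 1, so the two stand level on the numbers available. Compound 3 `Cn1cnc(-c2ccc(OC(F)(F)F)c(NC(=O)Nc3ccncc3)c2)c1` departs from compound 2 in one place: 1-methyl-1H-imidazol-4-yl in place of pyridin-3-yl on an aromatic carbon. Here 1-methyl-1H-imidazol-4-yl stands in place of pyridin-3-yl on an aromatic carbon, para to a trifluoromethoxy group. Among the measured compounds shown here, no measured pair of compounds differing in one place is available as a guide to this change. In this assay, therefore, no shift beyond the scatter is expected in either direction. The expected change is small, with an estimated 1.2-fold lower number from compound 2 to compound 3 (0.09 log units; within the scatter). The estimate for compound 3 is 35000 nM, with an expected range from 12000 nM to 90000 nM.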

Compound 3, half-maximal inhibitory concentration: > 300000 nM
Compound 3: a limit, no number; the forecaster's own chance of this, stated with the estimate: 15%; middle value at least 8.5-fold (0.93 log units) from the limit.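

Among these compounds, on the aromatic carbon para to a trifluoromethoxy group, the earlier compounds offered no step to read, and here a change at that place is seen to matter in this assay: 1-methyl-1H-imidazol-4-yl in place of pyridin-3-yl brings an at least 7.0-fold higher number from compound 2 to compound 3 (0.84 log units; beyond the scatter). The two groups hold the same number of heavy atoms and neither carries a net charge, yet they part in ring size and in hetero atoms, so matching size alone does not keep the reading at this place. On these data alone, compound 3 stands as a limit of the assay and not as a number, so the full size of the step stays unknown: the limit of > 300000 nM in this assay, at which 1 of the 3 values shown sits.

As far as these compounds go, whether the five-membered ring or its methyl group goes with the loss remains open. From the compounds shown here alone, how a simple phenyl ring, an amine or a carboxylic acid would read at this place also remains open.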